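The source may hold more compounds than are shown below. What is called first, only, known or untested is meant among the compounds shown, and "the series" means these compounds.

Three compounds with a shared core bearing a methyl-substituted, oxygen-containing ring have been tested in a functional assay on the whole organism for inhibition, with Rattus norvegicus as the target, read by paw edema, with a stated time of 1 h, at a dose of 50 mg/kg; on this read-out higher numbers stand for more inhibition at the one dose given (going by the name of the read-out) and lower numbers for less inhibition. Compound 1 `CC(=O)c1c(NNc2ccc(Br)cc2)cc(C)oc1=O` gives 46.8% in this assay. Compound 2 `CC(=O)c1c(NNc2nc(-c3ccccc3)cs2)cc(C)oc1=O` gives 51.9%. Compound 3 `Cc1cc2nn(-c3ccccc3)c(C)c2c(=O)o1`, in which a phenyl sits on a fused ring rather than on a hydrazine linker, gives 57%. Among these three numbers the value of compound 3 is the highest, yet its gap to compound 2 lies within the usual scatter of repeated measurements, so the two cannot be told apart, while its gap to compound 1 lies beyond that scatter.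

Compound 4 `COc1ccc(-n2nc3cc(C)oc(=O)c3c2C)cc1` has not yet been measured. It differs from compound 3 in one place: methoxy in place of hydrogen on an aromatic carbon. Among the compounds with values here, no measured pair in this set separates the effect of such a change, so there is no direct precedent to draw on. The step of no change at the digits printed from compound 3 to compound 4 (within the scatter) is expected to stay within the scatter, with no clear direction. In this assay compound 4 is therefore estimated at 57%, with a range from 42% to 71%.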

Compound 4, a percentage reported as inhibition, in the whole organism at one dose (the size of the read-out at that dose, not a potency): 64.6%
The estimate for compound 4 lay 7.6 percentage points below the measured number; the range from low to high includes it.
By their numbers in this assay, from the lowest: compounds 1, 2, 3 and 4 (each within the scatter of the next, the first and the last beyond it).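

In this assay, within the data shown here, the methoxy change gives a number 7.6 percentage points higher from compound 3 to compound 4 (within the scatter), and this is the first pair in the set that differs in one place. It shows that methoxy can stand in place of hydrogen on this aromatic carbon, para to a large group, with no difference that can be told from scatter at the one dose given. Nothing measured here bears on the result, so the step remains without any stated cause.

The compounds shown leave open whether another group on this carbon, such as an amine, a carboxylic acid or a longer chain like butoxy, would give a step beyond the scatter. They also leave open whether methoxy on another carbon of the same ring would give a similar result.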